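A Trifluoromethylphenyl Replaces a Methylphenyl on the Ring Nitrogen

The compounds below may be only part of what the source reports. "The series", "measured", "known", "first", "only" and "open" are said of these compounds alone.

Compound 2 `Cc1cccc(-n2cc(CNC(=O)c3cccc4c3cnn4C(C)C)nn2)c1` is one of two compounds examined in a functional assay on MGC-803 cells (Homo sapiens) for inhibition, read by MTT assay, with a stated time of 72 h; on this read-out higher numbers stand for weaker inhibition and lower numbers for stronger inhibition. In this assay compound 2 gives only a limit, > 40000 nM. Compound 1 `CC(C)n1ncc2c(C(=O)NCc3cn(-c4ccccc4)nn3)cccc21` likewise gives only a limit, > 40000 nM. The step that the two limits leave unreadable from compound 1 to compound 2 cannot be read because of the limit of > 40000 nM in this assay, at which 2 of the 2 values shown sit. Compound 3 `CC(C)n1ncc2c(C(=O)NCc3cn(-c4ccc(C(F)(F)F)cc4)nn3)cccc21` carries 4-(trifluoromethyl)phenyl in place of 3-methylphenyl on an aromatic nitrogen. Among the compounds with values here, no measured step bears on this change, and both known values sit at the limit, so compound 3 is expected to give 40000 nM, within a range from 12000 nM to 120000 nM, an estimated step of a number no higher from compound 2 to compound 3 (the limit leaves the size open) not expected to exceed the scatter.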

Compound 3, half-maximal inhibitory concentration: > 40000 nM
Compound 3 was reported as a limit; the forecaster's own chance of this, stated with the estimate: 75%; the middle value lies on the limit itself.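

The steps from compound 1 and compound 2 to compound 3 cannot be read, because all three compounds stop at one limit: the limit of > 40000 nM in this assay, at which 3 of the 3 values shown sit.

The compounds shown leave open whether phenyl, 3-methylphenyl or 4-(trifluoromethyl)phenyl changes inhibition at all.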